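Second methoxy on the aryl ketone of the chalcone series

The source may report more compounds than this note shows. Statements on the series, on what has been measured and on what is new or still open speak of the compounds shown alone.

Three compounds of the series share one core and differ only in the aryl ketone. Compound 1 `COc1ccc(-c2cc3ccccc3nc2/C=C/C(=O)c2ccc(F)cc2)cc1` gives 8320 nM in a functional assay on A549 cells (Homo sapiens) for antiproliferative activity, read by XTT assay, with a stated time of 72 h; on this read-out higher numbers stand for weaker inhibition and lower numbers for stronger inhibition. Compound 2 `COc1ccc(-c2cc3ccccc3nc2/C=C/C(=O)c2ccc(O)cc2)cc1` gives 7440 nM in this assay, and compound 3 `COc1ccc(C(=O)/C=C/c2nc3ccccc3cc2-c2ccc(OC)cc2)cc1` gives 8500 nM. None of the three is separated from another beyond the scatter: the change from compound 1 to compound 2 reads a 1.1-fold lower number from compound 1 to compound 2 (0.05 log units; within the scatter), from compound 1 to compound 3 a 1.0-fold higher number from compound 1 to compound 3 (0.01 log units; within the scatter), and from compound 2 to compound 3 a 1.1-fold higher number from compound 2 to compound 3 (0.06 log units; within the scatter). Within the data shown here, compound 3 therefore stands level with compounds 1 and 2 on the numbers so far.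

Compound 4 `COc1ccc(-c2cc3ccccc3nc2/C=C/C(=O)c2ccc(OC)cc2OC)cc1` takes the next step: methoxy in place of hydrogen on an aromatic carbon. Among the measured compounds shown here, no measured step adds a second substituent to this ring; the nearest evidence is the exchange of the single para group, where fluoro, hydroxy and methoxy all gave numbers within the scatter of one another. On that basis the added methoxy is expected to leave the number essentially unchanged, with no step beyond the scatter in either direction, so that a 1.0-fold higher number from compound 3 to compound 4 (0.02 log units; within the scatter) is estimated. Compound 4 is thus expected to give about 8800 nM in this assay, within a range from 4200 nM to 18500 nM.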

Compound 4, half-maximal inhibitory concentration: 7990 nM
For compound 4 the middle estimate is 1.1-fold (0.04 log units) above the measured one; measured number inside the range.
By their numbers in this assay, from the lowest: compounds 2, 4, 1 and 3 (each within the scatter of the next).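

In this assay, among these compounds, the step from 4-methoxyphenyl to 2,4-dimethoxyphenyl, the only one here that adds a substituent to the aryl ketone ring rather than exchanging its single group, reads a 1.1-fold lower number from compound 3 to compound 4 (0.03 log units; within the scatter). Set against the rings with one substituent, the 2,4-dimethoxyphenyl ketone reads a 1.1-fold higher number from compound 2 to compound 4 (0.03 log units; within the scatter) and a 1.0-fold lower number from compound 1 to compound 4 (0.02 log units; within the scatter), so all steps among the four compounds now lie within the scatter, and a methoxy on the carbon ortho to a large group is the first sign that this ring can carry a second substituent with no step beyond it. No measurement on hand offers a reason for these numbers.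

With no step beyond the scatter in the set, the compounds shown do not tell which feature of the aryl ketone, if any, governs the number in this assay. From the compounds shown here alone, whether an amine, a carboxylic acid or a longer chain such as butoxy on this ring would give a step beyond the scatter remains open, as does the effect of any change to the shared core.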